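Chloro to methylsulfanyl: a small swap

A few compounds are considered here, and "the series" means these few. Any claim that something is new, unique, unknown or untested is made for them only; others in the source may bear on it.

compound 1 `O=C(CCc1cccc2c1B(O)OC2)Nc1cccc(I)c1` gives 2300 nM
compound 2 `O=C(CCc1cccc2c1B(O)OC2)Nc1cccc(-c2cccc(F)c2)c1` gives 460 nM
compound 3 `O=C(CCc1cccc2c1B(O)OC2)Nc1cccc(-c2cccc(Cl)c2)c1` gives 350 nM

These three compounds were compared in a functional assay on HCT-116 cells (Homo sapiens) for antiproliferative activity, read by MTT assay, with a stated time of 72 h (a higher number here means a weaker inhibitor, a lower number a stronger inhibitor), and differ only in one group on the shared core. Putting 3-fluorophenyl in place of iodo gives a 5.0-fold lower number from compound 1 to compound 2 (0.70 log units; beyond the scatter) and putting 3-chlorophenyl in its place gives a 6.6-fold lower number from compound 1 to compound 3 (0.82 log units; beyond the scatter) so compound 3 has a clearly lower number than compound 1. Compound 3 cannot be ranked against compound 2, as the gap between them lies within the scatter.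

The next structure is compound 4 `CSc1cccc(-c2cccc(NC(=O)CCc3cccc4c3B(O)OC4)c2)c1` which has methylsulfanyl in place of chloro on an aromatic carbon and so turns 3-chlorophenyl into 3-(methylsulfanyl)phenyl. The two steps away from compound 1 replace a whole group and say little about this smaller swap. The closest guide is the exchange of fluoro for chloro, which gives a 1.3-fold lower number from compound 2 to compound 3 (0.12 log units; within the scatter) and suggests that this substituent matters little. For the measured compounds named here, that is a single step, however, and no measured compound carries methylsulfanyl. The expected change is a 1.1-fold higher number from compound 3 to compound 4 (0.06 log units; within the scatter) and so no step beyond the scatter is expected. For compound 4 the estimated value is 400 nM within an expected range from 170 nM to 900 nM for repeated measurements.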

Compound 4, half-maximal inhibitory concentration: 110 nM
The estimate for compound 4 lay 3.6-fold (0.56 log units) above the measured number; the whole stated range lies above it.
By their numbers in this assay, from the lowest: compound 4; then compounds 3 and 2 (each within the scatter of the next); then compound 1.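

In this assay, the substituent at this position does matter: methylsulfanyl in place of chloro gives a 3.2-fold lower number from compound 3 to compound 4 (0.50 log units; beyond the scatter), whereas the exchange of fluoro for chloro gave only a 1.3-fold lower number from compound 2 to compound 3 (0.12 log units; within the scatter), a gap within the scatter. Methylsulfanyl also stands clear of the fluoro compound, with a 4.2-fold lower number from compound 2 to compound 4 (0.62 log units; beyond the scatter), and the step from the iodo compound, a 21-fold lower number from compound 1 to compound 4 (1.32 log units; beyond the scatter), is the only large one in the set, which makes compound 4 the strongest inhibitor of the four. Nothing available explains why this small swap lowers the number.

The compounds shown leave open whether the lower number goes with the sulfur or with the added carbon, and a methoxy or a methyl group at this position would help to separate the two, while ethylsulfanyl, a longer chain, would show whether more length lowers the number further. They also leave open whether methylsulfanyl would give a similar step elsewhere on this ring, as the substituents on this ring in compounds 2, 3 and 4 all stand at this one place.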